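Solubility notes: bicyclic heteroaryl to 2-fluorophenyl on the chain

A few compounds are considered here, and "the series" means these few. Any claim that something is new, unique, unknown or untested is made for them only; others in the source may bear on it.

Compound 3 `CNC(=O)c1cc(C(=O)NC2CC2)cn(Cc2cccc3[nH]ncc23)c1=O` is the lowest of the three measured compounds in a physicochemical assay for solubility, read by HPLC, in simulated intestinal fluid, with a stated time of 16 h, tested at 125 ug/mL (on this read-out lower numbers stand for lower solubility and higher numbers for higher solubility), giving 4 ug/mL. Compound 1 `CNC(=O)c1cc(C(=O)NC2CC2)cn(Cc2cccc3cc[nH]c23)c1=O` gives 11 ug/mL in this assay, and compound 2 `CNC(=O)c1cc(C(=O)NC2CC2)cn(Cc2cccc3cn[nH]c23)c1=O` gives 131 ug/mL. The measured steps are a 12-fold higher number from compound 1 to compound 2 (1.08 log units; beyond the scatter), a 2.8-fold lower number from compound 1 to compound 3 (0.44 log units; beyond the scatter) and a 33-fold lower number from compound 2 to compound 3 (1.52 log units; beyond the scatter); all three only move nitrogens within the bicyclic group, and none swaps that group for a single ring. Compound 4 `CNC(=O)c1cc(C(=O)NC2CC2)cn(Cc2ccccc2F)c1=O` differs from compound 3 as follows: 2-fluorophenyl in place of 1H-indazol-4-yl on a saturated chain carbon bound to an aromatic nitrogen. Among the compounds with values here, no measured step bears directly on this change, so the expectation rests on the loss of one ring and its donor and acceptor. Compound 4 is expected to give 15 ug/mL in this assay, within 4 ug/mL to 60 ug/mL, a step of a 3.8-fold higher number from compound 3 to compound 4 (0.57 log units; beyond the scatter).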

Compound 4, solubility: 88 ug/mL
The estimate for compound 4 lay 5.9-fold (0.77 log units) below the measured number; measured number outside the range, above it.
By their numbers in this assay, from the lowest: compound 3; then compound 1; then compounds 4 and 2 (each within the scatter of the next).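

In this assay the 2-fluorophenyl group gives a 22-fold higher number from compound 3 to compound 4 (1.34 log units; beyond the scatter) and an 8.0-fold higher number from compound 1 to compound 4 (0.90 log units; beyond the scatter) and stands level with the 1H-indazol-7-yl group, with a 1.5-fold lower number from compound 2 to compound 4 (0.17 log units; within the scatter) within the scatter. A single aromatic ring with no hydrogen-bond donor or acceptor on the saturated chain carbon therefore reaches the level of the best bicyclic group shown. No measurement here accounts for these steps. From the compounds shown here alone, how an unsubstituted phenyl or a pyridine ring would read at this place remains open, as does whether an amine or a carboxylic acid on the phenyl ring would shift the number.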